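The source may hold more compounds than are shown below. What is called first, only, known or untested is meant among the compounds shown, and "the series" means these compounds.

Measured compounds:
Compound 1 `CN(C)CCNc1nc(-c2ccc(NC(=O)Nc3ccc(F)cc3)cc2)nc2ccsc12`: 390 nM
Compound 2 `CCN(CC)CCCNc1nc(-c2ccc(NC(=O)Nc3ccccc3)cc2)nc2ccsc12`: 680 nM

Both were tested in a functional assay on NCI-H460 cells (Homo sapiens) for cytotoxicity, read by MTT assay, with a stated time of 72 h; on this read-out lower numbers stand for stronger inhibition and higher numbers for weaker inhibition. Among the compounds with values here, compound 2 shows the higher of the two numbers, but its only neighbour, compound 1, sits within the usual scatter, so nothing separates them. Compound 3 `CCN(CC)CCCNc1nc(-c2ccc(NC(=O)Nc3ccc(F)cc3)cc2)nc2ccsc12` differs from compound 2 by fluoro in place of hydrogen on an aromatic carbon. Within the data shown here, no measured pair isolates this change. Compound 1 and compound 2 differ in two places, so their values say nothing about the fluoro alone. The expectation for compound 3 is therefore a step of a 1.3-fold lower number from compound 2 to compound 3 (0.12 log units; within the scatter) in this assay, nothing beyond the scatter. Compound 3 is estimated at 520 nM, with a range from 220 nM to 1250 nM.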

Compound 3, half-maximal inhibitory concentration: 290 nM
The estimate for compound 3 lay 1.8-fold (0.25 log units) above the measured number; low and high end bracket the measured number.
By their numbers in this assay, from the lowest: compounds 3, 1 and 2 (each within the scatter of the next, the first and the last beyond it).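

In this assay, within the data shown here, the change from phenyl to 4-fluorophenyl, with fluoro in place of hydrogen para to a large group, gives a 2.3-fold lower number from compound 2 to compound 3 (0.37 log units; beyond the scatter), a modest effect and the first reading of this change alone. The other change, (diethylamino)methyl in place of dimethylamino, gives a 1.3-fold lower number from compound 1 to compound 3 (0.13 log units; within the scatter), so it separates nothing here. Nothing available explains the fluoro step. The compounds shown leave open whether chloro or methoxy at that place would behave like fluoro. They also leave open whether the fluoro step carries over to the dimethylamino side chain of compound 1.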